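The compounds below may be only part of what the source reports. "The series", "measured", "known", "first", "only" and "open" are said of these compounds alone.

Compound 1 `O=C(Nc1cccc(-c2ccco2)c1)C1CCCN(C(=O)c2cc(C(F)(F)F)cc(C(F)(F)F)c2)C1` gives 0%. Compound 2 `Cc1nc(-c2cccc(C(=O)N3CCCC(C(=O)Nc4ccc(Cl)cc4)C3)c2)no1` gives 0%.

In an ADME assay on PC-3 cells (Homo sapiens) for cytotoxicity, read by WST assay, tested at 100 uM (on this read-out lower numbers stand for less inhibition and higher numbers for more inhibition at the one concentration tested (going by the name of the read-out)), compound 2 stands level with compound 1 at the digits shown, the two values within the scatter of each other. Compound 3 `CC(=O)Nc1cccc(C(=O)N2CCCC(C(=O)Nc3ccc(Cl)cc3)C2)c1` is not yet measured; it differs from compound 2 by acetamido in place of 5-methyl-1,2,4-oxadiazol-3-yl on an aromatic carbon. For the measured compounds named here, no step between measured compounds is known here, and both measured compounds sit at the floor of the read-out. The step from compound 2 to compound 3 is expected to be a number 2 percentage points higher from compound 2 to compound 3 (within the scatter), none beyond the scatter. Compound 3 is therefore estimated at 2%, with a range from 0% to 12%.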

Compound 3, a percentage reported as inhibition, at one concentration (the size of the read-out at that concentration, not a potency): 4%
For compound 3 the middle estimate is 2 percentage points below the measured one; measured number inside the range.
By their numbers in this assay, from the lowest: compounds 1, 2 and 3 (each within the scatter of the next).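

Putting acetamido in place of 5-methyl-1,2,4-oxadiazol-3-yl on an aromatic carbon gives a number 4 percentage points higher from compound 2 to compound 3 (within the scatter) in this assay. At this position, meta to a large group, a group with no ring and one with a five-membered aromatic ring therefore cannot be told apart on this read-out. No measured evidence offers an explanation for this result.

As far as these compounds go, whether an amine or a carboxylic acid at this position would give a number beyond the scatter remains open. So does whether a change elsewhere on the shared core, such as a longer chain in place of the acetamido methyl, would move the read-out.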